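Replacing an acetyl methyl by a hydroxylated branch

The compounds below may be only part of what the source reports. "The series", "measured", "known", "first", "only" and "open" are said of these compounds alone.

Compound 1, with the structure `CC(=O)Nc1cc(Oc2ccc(Nc3nccc4[nH]cc(-c5ccc(F)cc5)c(=O)c34)cc2F)ccn1`, was tested in a functional assay on HT-29 cells (Homo sapiens) for antiproliferative activity, read by MTT assay, with a stated time of 72 h, tested at 10 uM (on this read-out higher numbers stand for more inhibition at the one concentration tested (going by the name of the read-out) and lower numbers for less inhibition), and here compound 1 gives 36.8%. Among the two measured compounds, compound 1 holds the higher number. Going by the values given here, the only comparison available is with compound 2, `O=C(Nc1cc(Oc2ccc(Nc3nccc4[nH]cc(-c5ccc(F)cc5)c(=O)c34)cc2F)ccn1)C1CC1`, in which compound 2 gives 25.5%. Among the compounds with values here, that pair forms the single measured step, a number 11.3 percentage points lower from compound 1 to compound 2 (beyond the scatter), so the one change tried so far at the carbonyl carbon of the amide lowered inhibition modestly.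

Compound 3, `CC(C)(O)C(=O)Nc1cc(Oc2ccc(Nc3nccc4[nH]cc(-c5ccc(F)cc5)c(=O)c34)cc2F)ccn1`, has not yet been measured. It differs from compound 1 by 1-hydroxy-1-methylethyl in place of methyl on a carbonyl carbon. Within the data shown here, this is the same position that was altered in going from compound 1 to compound 2, where the step was modest and downward, which is the only guide available; the entering group brings a donor and an acceptor that the cyclopropyl did not, so the earlier step is only a loose guide. On that basis a modest downward step of a number 8.8 percentage points lower from compound 1 to compound 3 (within the scatter) is expected for compound 3, with a real chance that the change stays within the scatter. The estimate for compound 3 is 28%, with a range from 12% to 45%.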

Compound 3, a percentage reported as inhibition, at one concentration (the size of the read-out at that concentration, not a potency): -2.9%
For compound 3 the middle estimate is 30.9 percentage points above the measured one, outside the stated range (below it).
By their numbers in this assay, from the lowest: compound 3; then compound 2; then compound 1.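

At the carbonyl carbon of the amide, the new group shows how much this position can matter in this assay: there is a number 39.7 percentage points lower from compound 1 to compound 3 (beyond the scatter), and there is also a number 28.4 percentage points lower from compound 2 to compound 3 (beyond the scatter). The cyclopropyl had suggested only a modest cost for changing the methyl, whereas with 1-hydroxy-1-methylethyl, compound 3 gives -2.9%, so the inhibition seen with the two earlier compounds does not carry over to this group. The change adds carbon atoms, branching and a hydroxyl at once, and no measurement available here accounts for the drop.

The compounds shown leave open whether the loss goes with the hydroxyl or with the branched carbon skeleton, and a tert-butyl group on the same carbonyl carbon would help to separate the two. They also leave open how an unbranched hydroxymethyl, an amine or a longer chain would behave there, and each of these numbers describes inhibition at only one concentration, not a potency.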